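Chloro for methoxy: permeability notes on the series

This account rests on a few compounds, and the source may have more. Where it says the series, first, only, none or still open, it means among the compounds named here.

Compound 1 `COc1ccc2c(=O)c(Cc3ccccc3)c(C)[nH]c2c1`, compound 2 `COc1cccc2[nH]c(C)c(Cc3ccccc3)c(=O)c12` and compound 3 `Cc1[nH]c2cc(Cl)ccc2c(=O)c1Cc1ccccc1` have been measured. In an ADME assay for permeability, using PAMPA, at pH 7.4 (on this read-out lower numbers stand for lower permeability and higher numbers for higher permeability), compound 1 gives 240 10^-6 cm/s, compound 2 gives 158 10^-6 cm/s and compound 3 gives 392 10^-6 cm/s. The step of a 1.6-fold higher number from compound 1 to compound 3 (0.21 log units; within the scatter) goes with the change (chloro in place of methoxy on an aromatic carbon). Compound 2 and compound 1 have the same atoms joined differently; the difference between the two cores is not broken down here. Compound 4 `Cc1[nH]c2cccc(Cl)c2c(=O)c1Cc1ccccc1` is not yet measured and differs from compound 2 by chloro in place of methoxy on an aromatic carbon. This is the same kind of change as from compound 1 to compound 3, though the place differs: ortho to a fused ring and meta to a fused ring here, against meta to a fused ring and para to a fused ring there. Because the measured step was a 1.6-fold higher number from compound 1 to compound 3 (0.21 log units; within the scatter), a comparable step is expected, a 1.6-fold higher number from compound 2 to compound 4 (0.20 log units; within the scatter). Compound 4 is therefore estimated at 250 10^-6 cm/s, between 130 10^-6 cm/s and 450 10^-6 cm/s.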

Compound 4, apparent permeability: 251 10^-6 cm/s
For compound 4 the middle estimate is 1.0-fold (0.00 log units) below the measured one, and the stated range covers the measured number.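

Chloro in place of methoxy on an aromatic carbon, read in this assay, gives a 1.6-fold higher number from compound 2 to compound 4 (0.20 log units; within the scatter), and the two steps on the two cores can be set side by side: the same change on two cores in this assay, a 1.6-fold higher number (0.21 log units; within the scatter) from compound 1 to compound 3 and a 1.6-fold higher number (0.20 log units; within the scatter) from compound 2 to compound 4, 1.0-fold (0.01 log units) apart, within the scatter of two such steps. The step therefore carries across these two cores without a gap beyond the scatter. Each step is itself within the scatter, so the agreement does not establish a real difference between chloro and methoxy, and two pairs say nothing about other cores or other places on the ring.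

Still open, as far as these compounds go, is how an amine or a carboxylic acid would read in place of methoxy at these places. From the compounds shown here alone, a longer chain such as butoxy also remains open.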